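Furan-2-yl for phenyl on the pyridine-type core

A few compounds are considered here, and "the series" means these few. Any claim that something is new, unique, unknown or untested is made for them only; others in the source may bear on it.

Measured compounds:
- compound 1 `Oc1ccccc1-c1cc(-c2ccccc2)cc(-c2ccccc2O)n1`: "not determined" (no result reported)
- compound 2 `Oc1ccc(-c2cc(-c3ccccc3)cc(-c3ccco3)n2)cc1`: "not determined" (no result reported)
- compound 3 `Oc1cccc(-c2cc(-c3ccccc3)nc(-c3ccccc3)c2)c1`: 0%

Among the compounds with values here, in an assay on isolated protein for inhibition of DNA topoisomerase 1 (Homo sapiens), with a stated time of 30 min, tested at 20 uM (on this read-out higher numbers stand for a stronger effect at the one concentration tested and lower numbers for a weaker effect), compound 3 gives 0% and is the only compound of the series with a number; for compound 1 and compound 2 no result is reported, so no step between measured compounds can be drawn. Compound 4 `Oc1cccc(-c2cc(-c3ccccc3)nc(-c3ccco3)c2)c1`, not yet measured, differs from compound 3 in one place: furan-2-yl in place of phenyl on an aromatic carbon. Within the data shown here, with a single measured point and no measured step, the change is expected to stay within the scatter in this assay, with a step of a number 5 percentage points higher from compound 3 to compound 4 (within the scatter) from compound 3 to compound 4 that is expected to be small. For compound 4 the estimate is 5%, within 0% to 25%, resting on compound 3 at 0%.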

Compound 4, a percentage reported as inhibition, at one concentration (the size of the read-out at that concentration, not a potency): 3.5%
The estimate for compound 4 lay 1.5 percentage points above the measured number; the measured number falls inside the stated range.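

In this assay, within the data shown here, furan-2-yl in place of phenyl next to the ring nitrogen gives a number 3.5 percentage points higher from compound 3 to compound 4 (within the scatter) and thus the first measured step. At this position, a five-membered aromatic ring with one oxygen and a six-membered carbon ring are not told apart by this read-out, with neither compound showing a clear effect. No measured data bear on the reason for this result.

Open, on these data alone, is whether an amine, a carboxylic acid or a longer alkyl chain at this position would give a step beyond the scatter. Also open, as far as these compounds go, is whether furan-2-yl behaves the same way on other positions of the shared core.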